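A few compounds are considered here, and "the series" means these few. Any claim that something is new, unique, unknown or untested is made for them only; others in the source may bear on it.

Measured in a functional assay on MDA-MB-231 cells (Homo sapiens) for antiproliferative activity, read by MTT assay, with a stated time of 72 h; on this read-out lower numbers stand for stronger inhibition and higher numbers for weaker inhibition:
- compound 1 `NC1=NC2(CCSCC2)N(OCCCOc2ccc(Cl)c(Cl)c2)C(N)=N1`: 10 nM
- compound 2 `CC(C)(C)c1ccc(OCCCON2C(N)=NC(N)=NC23CCSCC3)cc1`: 1 nM
- compound 3 `COc1ccc(OCCCON2C(N)=NC(N)=NC23CCOCC3)cc1`: "not determined" (no result reported)

Compound 3 has no place on this scale, since its entry in this assay reads "not determined" (no result reported). It therefore offers no number to start from. The next compound is compound 4 `NC1=NC2(CCOCC2)N(OCCCOc2ccccc2Cl)C(N)=N1`, which has not yet been measured. The structural change is 2-chlorophenyl in place of 4-methoxyphenyl on an oxygen on a saturated carbon.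

Among the compounds with values here, with no number for compound 3, no step in this assay can be sized, and neither a rise nor a fall is expected from it. The expectation has to lean on the two measured compounds instead. Compound 1, whose aromatic ring also carries chlorine, gives 10 nM, and compound 2 gives 1 nM. Both differ from compound 4 in the core as well, so the expected range is kept wide. For compound 4 the estimated value is 10 nM, with an expected range from 2 nM to 60 nM.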

Compound 4, half-maximal inhibitory concentration: 1430 nM
Compound 4: middle estimate off by 140-fold (2.16 log units), on the low side; measured number above the stated range.
By their numbers in this assay, from the lowest: compound 2; then compound 1; then compound 4.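

Compound 3 has no number in this assay, so the change from compound 3 to compound 4 cannot be sized as a step. No supporting data bear on the result for compound 4. Going by these compounds, whether the 2-chlorophenyl group or the core sets compound 4 apart from compound 1 and compound 2 stays open.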